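Nitro for Bromo on a Shared Thiazole-Triazole Scaffold

The compounds below may be only part of what the source reports. "The series", "measured", "known", "first", "only" and "open" are said of these compounds alone.

Compound 1 `COc1ccccc1-n1c(Nc2nc(-c3ccc([N+](=O)[O-])cc3)cs2)n[nH]c1=S`: 100 mg/kg
Compound 2 `COc1ccccc1-n1c(Nc2nc(-c3ccc(Br)cc3)cs2)n[nH]c1=S`: 300 mg/kg
Compound 3 `Cc1ccc(-n2c(Nc3nc(-c4ccc(Br)cc4)cs3)n[nH]c2=S)cc1`: 100 mg/kg

Of the compounds shown here, three have been measured in a functional assay on the whole organism (strain Swiss albino) for inhibition, with Mus musculus as the target, with a stated time of 0.5 h; a higher number here means that more compound is needed for the effect, a lower number that less compound is needed. In this assay compound 2 gives 300 mg/kg, and the two others come out lower: compound 1 gives 100 mg/kg and compound 3 gives 100 mg/kg, so compound 1 and compound 3 stand level with each other at the digits shown.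

Two changes lead away from compound 2. The first is the exchange described by nitro in place of bromo on an aromatic carbon, which made the step of a 3.0-fold lower number from compound 2 to compound 1 (0.48 log units; beyond the scatter). The second alters the group on the aromatic nitrogen, described by 4-methylphenyl in place of 2-methoxyphenyl on an aromatic nitrogen, and made the step of a 3.0-fold lower number from compound 2 to compound 3 (0.48 log units; beyond the scatter).

Compound 4 `Cc1ccc(-n2c(Nc3nc(-c4ccc([N+](=O)[O-])cc4)cs3)n[nH]c2=S)cc1` has not yet been measured. It carries the same exchange that turned compound 2 into compound 1, now applied to compound 3: nitro in place of bromo on an aromatic carbon. The place is worded the same in both cases, so it is the same change, only on the core of compound 3 rather than that of compound 2.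

From the compounds shown here alone, because the earlier step of a 3.0-fold lower number from compound 2 to compound 1 (0.48 log units; beyond the scatter) was beyond the scatter, a step of similar direction is expected here, a 2.0-fold lower number from compound 3 to compound 4 (0.30 log units; within the scatter), though it is unknown whether the two lowering changes add up when combined in one molecule. Compound 4 is therefore estimated at 50 mg/kg, with a range from 25 mg/kg to 150 mg/kg.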

Compound 4, minimum effective dose: 100 mg/kg
Compound 4: middle estimate off by 2.0-fold (0.30 log units), on the low side; measured number inside the range.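

In this assay, nitro in place of bromo now gives no change at the digits printed from compound 3 to compound 4 (within the scatter), so the lower number seen on the core of compound 2 does not carry over to the core of compound 3: the same change on two cores in this assay, a 3.0-fold lower number (0.48 log units; beyond the scatter) from compound 2 to compound 1 and no change at the digits printed (within the scatter) from compound 3 to compound 4, 3.0-fold (0.48 log units) apart, beyond the scatter of two such steps
The exchange on the aromatic nitrogen shows the same picture, with 4-methylphenyl in place of 2-methoxyphenyl giving no change at the digits printed from compound 1 to compound 4 (within the scatter), so that step also depends on the core that carries it: the same change on two cores in this assay, a 3.0-fold lower number (0.48 log units; beyond the scatter) from compound 2 to compound 3 and no change at the digits printed (within the scatter) from compound 1 to compound 4, 3.0-fold (0.48 log units) apart, beyond the scatter of two such steps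
Each change lowers the number when made alone on compound 2, but the two together in compound 4 add nothing further; this rests on only four compounds, and it does not show why each change counts on one core and not on the other, or whether the same would hold for any other group.

The compounds shown leave open whether a different group on that aromatic carbon, such as an amine or a carboxylic acid, would move the number on either core. They also leave open whether a longer chain or an unsubstituted phenyl on the aromatic nitrogen would take the number below the level shared by compound 1, compound 3 and compound 4.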